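Allyl-substituted aryl azoles at the assay limit

A few compounds are considered here, and "the series" means these few. Any claim that something is new, unique, unknown or untested is made for them only; others in the source may bear on it.

Measured so far in a functional assay on BV-2 cells (Mus musculus) for inhibition, read by Griess assay, with a stated time of 24 h; a higher number here means a weaker inhibitor, a lower number a stronger inhibitor:
compound 1 `C=CCc1ccc(OC)c(-c2cc(CO)on2)c1`, which reaches only the assay limit, > 200000 nM
compound 2 `C=CCc1ccc(O)c(-c2cc(CO)on2)c1`, which reaches only the assay limit, > 200000 nM
compound 3 `C=CCc1ccc(OC)c(-c2ccn(CC=C)n2)c1`, which reaches only the assay limit, > 200000 nM

Of the compounds shown here, three have been measured in this assay, and none gives a number: each sits at the limit of the assay, as the limit of > 200000 nM in this assay, at which 3 of the 3 values shown sit, records. Compound 1 and compound 2 share a core and differ by a single change, (hydrogen in place of methyl on an oxygen on an aromatic ring). Because both values are limits, the step that the two limits leave unreadable from compound 1 to compound 2 cannot be read in size or direction.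

Compound 3 carries a different core; how the two cores differ is not broken down here. Compound 4 `C=CCc1ccc(O)c(-c2ccn(CC=C)n2)c1` has not yet been measured in this assay. It stands to compound 3 as compound 2 stands to compound 1, by the same change at the same place: hydrogen in place of methyl on an oxygen on an aromatic ring.

What can be expected of compound 4 rests on compound 3 alone, whose value is a limit, and on the step from compound 1 to compound 2, which the two limits leave unreadable. Nothing among the three compounds points to a measurable number, so the expected step that the limit leaves unreadable from compound 3 to compound 4 is essentially nil. Compound 4 is therefore expected to give about 300000 nM in this assay, within a range from 100000 nM to 1000000 nM, most likely reported again as a limit rather than a number.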

Compound 4, half-maximal inhibitory concentration: 1200 nM
The estimate for compound 4 lay 250-fold (2.40 log units) above the measured number; the measured number lies below the stated range.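

In this assay, the change from methoxy to hydroxy on the core of compound 3 gives an at least 160-fold lower number from compound 3 to compound 4 (2.22 log units; beyond the scatter), so on this core the change leads from a limit to a measured number. On the core of compound 1 the same change leaves compound 2 without a number, and the step there cannot be read in size or direction, because both compounds stand at a limit: the limit of > 200000 nM in this assay, at which 3 of the 4 values shown sit. The change therefore carries no demonstrated effect from one core to the other: compound 4 shows that it can matter on one core, compound 2 goes against any general rule that a hydroxy group on the aromatic ring yields a measurable number, and the two pairs do not show how much the core itself contributes.

The compounds shown leave open whether a longer chain in place of the methyl on that oxygen, or an amine in place of the hydroxy, would also give a measurable number on the core of compound 3. They also leave open whether any other change to the core of compound 1 would yield a number in this assay.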